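The source may report more compounds than this note shows. Statements on the series, on what has been measured and on what is new or still open speak of the compounds shown alone.

Measured compounds:
compound 1 `CC(C)(C)Nc1c(C#N)c(F)c2c(N)nc(N)nc2c1Cl`: 5.4 ug/mL
compound 2 `CC(C)(C)Nc1c(C#N)c(F)c2c(N)nc(N)nc2c1F`: 16.2 ug/mL
compound 3 `CCCCNc1c(C#N)c(NCCCC)c2c(N)nc(N)nc2c1Cl`: 1.3 ug/mL

All three were tested in a functional assay on HepG2 cells (Homo sapiens) for cytotoxicity, read by MTT assay; on this read-out higher numbers stand for weaker inhibition and lower numbers for stronger inhibition. Compound 1 and compound 2 share one core and differ only by fluoro in place of chloro on an aromatic carbon; that change gave a 3.0-fold higher number from compound 1 to compound 2 (0.48 log units; beyond the scatter). Compound 3 has the lowest of the three measured numbers in this assay, beyond the scatter against both compound 1 and compound 2. How the core of compound 3 differs from the core of compound 1 is not broken down here.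

Compound 4 `CCCCNc1c(C#N)c(NCCCC)c2c(N)nc(N)nc2c1F` is not yet measured. It differs from compound 3 by fluoro in place of chloro on an aromatic carbon. This is the same kind of change as from compound 1 to compound 2, not the same: in compound 1 the place is ortho to a (tert-butyl)amino group and para to a fluoro group, whereas in compound 3 it is ortho to a butylamino group and para to a butylamino group.

Going by the values given here, a step of about a 3.0-fold higher number from compound 3 to compound 4 (0.48 log units; beyond the scatter) is expected from compound 3 to compound 4, resting on the single matched example, a 3.0-fold higher number from compound 1 to compound 2 (0.48 log units; beyond the scatter), with added uncertainty because the surroundings of the place differ. Compound 4 is therefore estimated at 3.9 ug/mL in this assay, within 1.5 ug/mL to 10 ug/mL.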

Compound 4, half-maximal inhibitory concentration: 2.6 ug/mL
For compound 4 the middle estimate is 1.5-fold (0.18 log units) above the measured one; low and high end bracket the measured number.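

In this assay, fluoro in place of chloro on the aromatic carbon gives a 2.0-fold higher number from compound 3 to compound 4 (0.30 log units; within the scatter), so on this core the two compounds are not separated by the change. Set beside the earlier step, the change carries from one core to the other with no difference in size that can be told apart: the same change on two cores in this assay, a 3.0-fold higher number (0.48 log units; beyond the scatter) from compound 1 to compound 2 and a 2.0-fold higher number (0.30 log units; within the scatter) from compound 3 to compound 4, 1.5-fold (0.18 log units) apart, within the scatter of two such steps. Going by these compounds alone, this is agreement between only two pairs, one step beyond the scatter and the other within it, and it does not show a fixed step that would hold on a further core, nor does it say how the surroundings of the place bear on the step.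

The compounds shown leave open whether bromo or plain hydrogen on the same aromatic carbon would fit with these two steps. They also leave open whether the step survives when the butylamino groups give way to a longer chain or to a cyclic amine such as morpholine.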